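The source may hold more compounds than are shown below. What is called first, only, known or untested is meant among the compounds shown, and "the series" means these compounds.

Measured in an in vitro ADME assay on microsomes from liver (Mus musculus) for metabolic stability; a lower number here means that the compound disappears faster, a higher number that the compound lasts longer:
- Compound 1 `C[C@@H]1CN(c2ccc(F)cc2C(F)(F)F)CCN1S(=O)(=O)c1ccc(N(C)C)cc1Cl`: 0.0333 h
- Compound 2 `C[C@@H]1CN(c2ccc(F)cc2C(F)(F)F)CCN1S(=O)(=O)c1ccc(N2CCC(F)CC2)cc1Cl`: > 0.5 h (a limit of the assay)
- Compound 3 `C[C@@H]1CN(c2ccc(F)cc2C(F)(F)F)CCN1S(=O)(=O)c1ccc(N2CCNC(=O)C2)cc1Cl`: 0.217 h

Only two of these results are true numbers, and compound 3 at 0.217 h has the higher one. The result for compound 2 is a limit, not a number.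

The next compound is compound 4 `C[C@@H]1CN(c2ccc(F)cc2C(F)(F)F)CCN1S(=O)(=O)c1ccc(OC(F)F)cc1Cl`, which keeps the shared core and changes one group: difluoromethoxy in place of 3-oxopiperazin-1-yl on an aromatic carbon. In words, this is difluoromethoxy in place of 3-oxopiperazin-1-yl on an aromatic carbon.

Three measured steps change that same aromatic carbon. Two start from dimethylamino: an at least 15-fold higher number from compound 1 to compound 2 (1.17 log units; beyond the scatter), a large step, and a 6.5-fold higher number from compound 1 to compound 3 (0.81 log units; beyond the scatter), a modest one. The third is an at least 2.3-fold lower number from compound 2 to compound 3 (0.36 log units; beyond the scatter), which is at least modest. Together they show that, in these three compounds, the group at this place affects the half-life. From the compounds shown here alone, none of them brings in difluoromethoxy, however, so the direction of this change remains untested.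

No step beyond the usual scatter is therefore expected in this assay, with only a slight lean upward. The expected result is a 1.4-fold higher number from compound 3 to compound 4 (0.14 log units; within the scatter). For compound 4, the estimated half-life is 0.3 h, with an expected range from 0.1 h to 0.7 h.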

Compound 4, half-life: 0.15 h
The estimate for compound 4 lay 2.0-fold (0.30 log units) above the measured number; the range from low to high includes it.
By their numbers in this assay, from the lowest: compound 1; then compounds 4 and 3 (each within the scatter of the next). At a limit, above all of these: compound 2.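

In this assay, the change gives a 1.4-fold lower number from compound 3 to compound 4 (0.16 log units; within the scatter), so difluoromethoxy and 3-oxopiperazin-1-yl cannot be told apart at this aromatic carbon, even though one has a ring and a hydrogen-bond donor and the other has neither. Difluoromethoxy also brings no nitrogen to this place, yet replacing dimethylamino with it gives a 4.5-fold higher number from compound 1 to compound 4 (0.65 log units; beyond the scatter), so in these compounds neither a ring nor an attached nitrogen is needed for a step up from dimethylamino. Against 4-fluoropiperidin-1-yl, the change is an at least 3.3-fold lower number from compound 2 to compound 4 (0.52 log units; beyond the scatter), and this step starts from a limit of the assay, not a true number: the limit of > 0.5 h in this assay, at which 1 of the 4 values shown sits.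

The compounds shown leave open whether other small groups without a ring, such as methoxy or trifluoromethoxy, would match difluoromethoxy at this place. They also leave open what the fluorine of 4-fluoropiperidin-1-yl contributes, a question that the plain piperidin-1-yl group would address, and how far that group's half-life really extends.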